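The source may hold more compounds than are shown below. What is called first, only, known or untested is meant among the compounds shown, and "the series" means these compounds.

In a functional assay on HepG2 cells (Homo sapiens) for cytotoxicity, read by MTT assay, with a stated time of 72 h (on this read-out lower numbers stand for stronger inhibition and higher numbers for weaker inhibition), two compounds have been measured. Compound 1 `CNC(=O)c1cc(Oc2ccc(NC(=O)c3nn(-c4ccc(Br)cc4F)c(=O)cc3C)cc2F)ccn1` gives 2830 nM. Compound 2 `Cc1cc(=O)n(-c2ccccc2C(F)(F)F)nc1C(=O)Nc1ccc(Oc2ncnc3ccsc23)cc1` gives 9230 nM, the highest of the two numbers, and its nearest neighbour, compound 1, sits at a lower number by a gap beyond the scatter. Compound 3 `Cc1cc(=O)n(-c2ccc(F)c(F)c2)nc1C(=O)Nc1ccc(Oc2ncnc3ccsc23)cc1` differs from compound 2 in one place: 3,4-difluorophenyl in place of 2-(trifluoromethyl)phenyl on an aromatic nitrogen. Within the data shown here, no pair of measured compounds covers this change, so it is judged on its own. The step of a 1.3-fold lower number from compound 2 to compound 3 (0.12 log units; within the scatter) is expected to be small, toward a lower number if anything, and not beyond the scatter. Compound 3 is therefore estimated at 7000 nM, with a range from 2500 nM to 20000 nM.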

Compound 3, half-maximal inhibitory concentration: 9230 nM
The estimate for compound 3 lay 1.3-fold (0.12 log units) below the measured number; measured number inside the range.
By their numbers in this assay, from the lowest: compound 1; then compounds 2 and 3 (each within the scatter of the next).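

In this assay, among these compounds, putting 3,4-difluorophenyl in place of 2-(trifluoromethyl)phenyl on the aromatic nitrogen brings no change at the digits printed from compound 2 to compound 3 (within the scatter) and so gives the first reading at this position. With the rest of the molecule held the same, these two substituted phenyl groups cannot be told apart on this read-out. Nothing on hand offers an explanation for this result.

On these data alone, whether any group at this position can move the number beyond the scatter stays open. The compounds shown do not tell how a phenyl ring bearing an amine or a carboxylic acid, or a longer alkyl chain, would read there.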